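The source may report more compounds than this note shows. Statements on the series, on what has been measured and on what is new or still open speak of the compounds shown alone.

In a functional assay on MDA-MB-436 cells (Homo sapiens) for antiproliferative activity, read by MTT assay, with a stated time of 48 h (on this read-out higher numbers stand for weaker inhibition and lower numbers for stronger inhibition), three compounds sharing one core have been measured. Compound 1 `C=CS(=O)(=O)N1CCN(c2ncnc3sc(-c4ccc(OC)nc4)cc23)CC1` gives 11900 nM, compound 2 `C=CS(=O)(=O)N1CCN(c2ncnc3sc(-c4cc(Br)cnc4F)cc23)CC1` gives 28400 nM, and compound 3 `C=CS(=O)(=O)N1CCN(c2ncnc3sc(-c4cccs4)cc23)CC1` gives 39000 nM. Compound 3 thus sits at the high end of these numbers together with compound 2, within the scatter of it and clearly apart from compound 1. The unmeasured compound 4 `C=CS(=O)(=O)N1CCN(c2ncnc3sc(C4=CCCCC4)cc23)CC1` differs from compound 3 at a single place: cyclohex-1-en-1-yl in place of thiophen-2-yl on an aromatic carbon. In words, cyclohex-1-en-1-yl stands in place of thiophen-2-yl on an aromatic carbon, next to the ring sulfur. Three measured steps at this place bear on the change. Two are modest, a 2.4-fold higher number from compound 1 to compound 2 (0.38 log units; beyond the scatter) and a 3.3-fold higher number from compound 1 to compound 3 (0.52 log units; beyond the scatter), while a 1.4-fold higher number from compound 2 to compound 3 (0.14 log units; within the scatter) stays within the scatter. Among the compounds with values here, none of them brings in a non-aromatic ring, so the data hold no direct precedent for the entering group. The largest change seen here is only the modest 3.3-fold higher number from compound 1 to compound 3 (0.52 log units; beyond the scatter), and so no step beyond the scatter is expected in this assay, in either direction. The estimated step is a 1.2-fold lower number from compound 3 to compound 4 (0.09 log units; within the scatter), and it is expected to remain within the scatter. The expected value for compound 4 is 32000 nM, with an estimated range from 13000 nM to 75000 nM.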

Compound 4, half-maximal inhibitory concentration: > 50000 nM
Compound 4 was reported as a limit; the forecaster's own chance of this, stated with the estimate: 15%; middle value at least 1.5-fold (0.19 log units) from the limit.
By their numbers in this assay, from the lowest: compound 1; then compounds 2 and 3 (each within the scatter of the next). At a limit, above all of these: compound 4.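

In this assay, compound 4 is reported only as a limit, not as a number: the limit of > 50000 nM in this assay, at which 1 of the 4 values shown sits. Measured against compound 1, the change reads as an at least 4.2-fold higher number from compound 1 to compound 4 (0.62 log units; beyond the scatter), so the first non-aromatic ring shown on this aromatic carbon stands clearly apart from the 6-methoxypyridin-3-yl group. Against the other two compounds, the floors of an at least 1.7-fold higher number from compound 2 to compound 4 (0.24 log units; that floor lies within the scatter) and an at least 1.2-fold higher number from compound 3 to compound 4 (0.10 log units; that floor lies within the scatter) lie within the scatter, so these steps alone do not separate cyclohex-1-en-1-yl from 5-bromo-2-fluoropyridin-3-yl or from thiophen-2-yl. The new compound adds no lower number at this place, where compound 1 still has the lowest value at 11900 nM.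

As far as these compounds go, how far compound 4 really lies from compound 3 stays open, since only a floor can be read for that step. The compounds shown also leave open whether the double bond of the entering ring matters, which a saturated cyclohexyl group would address, and whether an amine such as a piperidine or a carboxylic acid on this carbon would bring the number down.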